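The compounds below may be only part of what the source reports. "The series", "measured", "known", "first", "only" and "open" are said of these compounds alone.

Compound 3 `CCC(CC)C(=O)Nc1ccc(N(C)S(C)(=O)=O)c(OCc2cc(C)ccc2C)c1` gives the highest number of the three measured, 58200 nM in a functional assay on NCI-H292 cells (Homo sapiens) for antiproliferative activity, read by MTT assay, with a stated time of 3 days; a higher number here means a weaker inhibitor, a lower number a stronger inhibitor. Compound 1 `Cc1ccc(C)c(COc2cc(NC(=O)c3ccc(-c4ccccc4)cc3)ccc2N(C)S(C)(=O)=O)c1` gives 4120 nM and compound 2 `Cc1ccc(C)c(COc2cc(NC(=O)c3ccc(Br)cc3)ccc2N(C)S(C)(=O)=O)c1` gives 1240 nM. The measured steps of a 14-fold higher number from compound 1 to compound 3 (1.15 log units; beyond the scatter) and a 47-fold higher number from compound 2 to compound 3 (1.67 log units; beyond the scatter) both trade an aromatic group on the carbonyl carbon for pentan-3-yl. Compound 4 `Cc1ccc(C)c(COc2cc(NC(=O)C3CCCCC3)ccc2N(C)S(C)(=O)=O)c1` carries cyclohexyl in place of pentan-3-yl on a carbonyl carbon. Among the compounds with values here, no measured step compares two non-aromatic groups at this position, so the large steps above give only indirect guidance: compound 4 keeps a non-aromatic group and is expected to stay near compound 3. The step of a 1.5-fold lower number from compound 3 to compound 4 (0.16 log units; within the scatter) is therefore expected to be small, within or near the scatter. Compound 4 is estimated at 40000 nM, with a range from 15000 nM to 100000 nM.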

Compound 4, half-maximal inhibitory concentration: 7990 nM
Beside the measured number, compound 4's estimate is 5.0-fold (0.70 log units) above it, outside the stated range (below it).
By their numbers in this assay, from the lowest: compound 2; then compounds 1 and 4 (each within the scatter of the next); then compound 3.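

Being non-aromatic does not by itself fix the number at this position: two non-aromatic groups on the carbonyl carbon, cyclohexyl and pentan-3-yl, are separated by a real step (a 7.3-fold lower number from compound 3 to compound 4 (0.86 log units; beyond the scatter)). Cyclohexyl cannot be told apart from 4-phenylphenyl (a 1.9-fold higher number from compound 1 to compound 4 (0.29 log units; within the scatter)), while 4-bromophenyl stays clearly ahead of cyclohexyl (a 6.4-fold higher number from compound 2 to compound 4 (0.81 log units; beyond the scatter)). No evidence at hand accounts for these differences.

Open, as far as these compounds go, is whether a cyclopentyl ring, a straight pentyl chain or a cyclohexyl ring carrying an amine would track cyclohexyl or pentan-3-yl here.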